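Swapping the aryl group on a cyanoacrylamide chain

This account rests on a few compounds, and the source may have more. Where it says the series, first, only, none or still open, it means among the compounds named here.

Measured compounds:
- compound 1, `N#C/C(=C\c1ccc[nH]1)C(=O)NCc1ccc(Cl)c(Cl)c1`: > 50000 nM in a functional assay on A2780 cells (Homo sapiens) for inhibition, read by MTT assay, with a stated time of 72 h; on this read-out lower numbers stand for stronger inhibition of growth and higher numbers for weaker inhibition of growth (a limit of the assay, not a number)
- compound 2, `COc1ccc(CNC(=O)/C(C#N)=C/c2ccco2)cc1`: 24000 nM
- compound 3, `COc1ccc(CNC(=O)/C(C#N)=C/c2ccc(C)cc2)cc1`: 33000 nM

All three share a core in which a nitrile and an amide sit on a double bond that carries an aromatic ring, and the amide nitrogen bears a benzyl group. Compound 1 stands at the edge of what this assay can report: its value is only a limit (the limit of > 50000 nM in this assay, at which 1 of the 3 values shown sits), so its true growth inhibition is weaker than any number shown. Compound 2 and compound 3 are within the scatter of each other.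

The unmeasured compound 4, `COc1ccc(/C=C(\C#N)C(=O)NCc2ccc(Cl)c(Cl)c2)cc1`, differs from compound 1 in one place: 4-methoxyphenyl in place of 1H-pyrrol-2-yl on a double-bonded chain carbon bound to a double-bonded chain carbon. The closest measured step is a 1.4-fold higher number from compound 2 to compound 3 (0.14 log units; within the scatter), where a five-membered aromatic ring also gave way to a six-membered ring of carbon only, with no shift beyond the scatter. On that basis a comparable change from compound 1 to compound 4 is expected to make little difference in this assay, and the result may again be a limit rather than a number. Compound 4 is therefore estimated at 45000 nM, within a range from 15000 nM to 150000 nM, a step of an at least 1.1-fold lower number from compound 1 to compound 4 (0.04 log units; that floor lies within the scatter) that is expected to stay within the scatter.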

Compound 4, concentration for 50% growth inhibition: 86000 nM
Beside the measured number, compound 4's estimate is 1.9-fold (0.28 log units) below it; measured number inside the range.
By their numbers in this assay, from the lowest: compounds 2 and 3 (each within the scatter of the next); then compound 4.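

The change from compound 1 to compound 4 gives no readable step, because compound 1 has only a limit and not a number to compare with: the limit of > 50000 nM in this assay, at which 1 of the 4 values shown sits.

The compounds shown leave open how much 4-methoxyphenyl in place of 1H-pyrrol-2-yl changes growth inhibition, since neither a size nor a direction can be taken from this pair.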